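Swapping the benzofuran for a cyanophenyl on a piperidine

The compounds below may be only part of what the source reports. "The series", "measured", "known", "first", "only" and "open" are said of these compounds alone.

Measured compounds:
- compound 1, `COc1ccc2nccc(C3CN(CC4CCCN(Cc5cc6ccccc6[nH]5)C4)C(=O)O3)c2c1`: < 50200 nM
- compound 2, `COc1ccc2nccc(C3CN(C4CCN(Cc5cc6ccccc6o5)CC4)C(=O)O3)c2c1`: 1260 nM

The two measured compounds share a core and differ in the ring attached to the saturated amine nitrogen and in the group hanging from it. In an in vitro functional assay on RBL cells for antagonist activity at C-C chemokine receptor type 8 (Homo sapiens), read by FLIPR and calcium flux (on this read-out higher numbers stand for weaker inhibition and lower numbers for stronger inhibition), compound 1 gives only a limit, < 50200 nM, and not a number. Compound 2 gives the only actual number shown, 1260 nM in this assay. Because (the limit of < 50200 nM in this assay, at which 1 of the 2 values shown sits), nothing can be said about how far apart compounds 1 and 2 truly lie.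

Compound 3, `COc1ccc2nccc(C3CN(C4CCN(Cc5ccc(C#N)cc5)CC4)C(=O)O3)c2c1`, has not been measured yet. It differs from compound 2 by 4-cyanophenyl in place of 1-benzofuran-2-yl on a saturated chain carbon bound to an amine nitrogen in a ring. The benzofuran-2-yl group that leaves brings two fused aromatic rings; the 4-cyanophenyl that enters brings a single six-membered ring with a nitrile. Among the compounds with values here, no measured pair shows what such a swap does here, so the expected step rests on the change alone. Compound 3 is expected to come out weaker than compound 2, by a 3.2-fold higher number from compound 2 to compound 3 (0.50 log units; beyond the scatter), a step beyond the usual scatter. The estimate for compound 3 in this assay is 4000 nM, with a range from 800 nM to 25000 nM.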

Compound 3, half-maximal inhibitory concentration: 12600 nM
For compound 3 the middle estimate is 3.2-fold (0.50 log units) below the measured one; the measured number falls inside the stated range.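

Within the data shown here, the swap from (1-benzofuran-2-yl)methyl to 4-cyanobenzyl gives the first step that can be read in this assay: a 10-fold higher number from compound 2 to compound 3 (1.00 log units; beyond the scatter). The group on this saturated chain carbon bound to an amine nitrogen in a ring therefore matters, since this single change with the rest of the molecule held constant makes inhibition clearly weaker, although compound 3 still gives a real number, 12600 nM, and not a limit. The earlier compounds could not show this, since compound 1 and compound 2 differ in more than one place and compound 1 gives only a limit, so no step can be read for that pair: the limit of < 50200 nM in this assay, at which 1 of the 3 values shown sits.

The swap removes the fused two-ring group and brings in the nitrile in one move, so these compounds cannot tell which of the two accounts for the step. A plain benzyl group on the same carbon would separate the two, and a benzyl group carrying an amine or a carboxylic acid in place of the nitrile would show how much the choice of substituent on that single ring counts.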